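The source may hold more compounds than are shown below. What is called first, only, known or untested is meant among the compounds shown, and "the series" means these compounds.

Measured in a functional assay on MDA-MB-231 cells (Homo sapiens) for antiproliferative activity, read by MTT assay, with a stated time of 72 h; a higher number here means a weaker inhibitor, a lower number a stronger inhibitor:
Compound 1 `O=C(CCc1cccc2c1B(O)OC2)Nc1cccc(Br)c1`: 720 nM
Compound 2 `CSc1ccc(-c2cccc(NC(=O)CCc3cccc4c3B(O)OC4)c2)cc1`: 140 nM
Compound 3 `O=C(CCc1cccc2c1B(O)OC2)Nc1cccc(-c2cccc(C(F)(F)F)c2)c1`: 410 nM

Compound 3 cannot be told apart from the bromo compound, compound 1, as the record gives a 1.8-fold lower number from compound 1 to compound 3 (0.24 log units; within the scatter). It does stand apart from compound 2, with a 2.9-fold higher number from compound 2 to compound 3 (0.47 log units; beyond the scatter).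

The next compound, compound 4 `N#Cc1ccc(-c2cccc(NC(=O)CCc3cccc4c3B(O)OC4)c2)cc1`, carries 4-cyanophenyl in place of 3-(trifluoromethyl)phenyl on an aromatic carbon, meta to a large group: 4-cyanophenyl in place of 3-(trifluoromethyl)phenyl on an aromatic carbon. Among the compounds with values here, no measured compound holds a nitrile, so the guidance is indirect. Within the data shown here, the closest precedent is the exchange of one substituted phenyl for another, a 2.9-fold higher number from compound 2 to compound 3 (0.47 log units; beyond the scatter), which read in reverse favours the 4-substituted phenyl of compound 2. That group also gave a 5.1-fold lower number from compound 1 to compound 2 (0.71 log units; beyond the scatter). Among the measured compounds shown here, with only one such compound, this is a weak pattern, and compound 3 shows that an added phenyl need not move the number beyond the scatter. A small drop in this assay is therefore expected, no larger than the gap between compound 2 and compound 3, and it may well stay within the scatter. The expected step is a 1.8-fold lower number from compound 3 to compound 4 (0.25 log units; within the scatter). For compound 4 the estimate is 230 nM, with an expected range of 90 nM to 580 nM.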

Compound 4, half-maximal inhibitory concentration: 380 nM
Beside the measured number, compound 4's estimate is 1.7-fold (0.22 log units) below it; the measured number falls inside the stated range.
By their numbers in this assay, from the lowest: compound 2; then compounds 4, 3 and 1 (each within the scatter of the next).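

In this assay, 4-cyanophenyl and 3-(trifluoromethyl)phenyl cannot be told apart at this position (a 1.1-fold lower number from compound 3 to compound 4 (0.03 log units; within the scatter)), and compound 4 also stays within the scatter of the bromo compound (a 1.9-fold lower number from compound 1 to compound 4 (0.28 log units; within the scatter)), so compound 4 joins compound 3 in showing that an added substituted phenyl need not separate a compound from compound 1. The new information lies in the comparison with compound 2, where the same 4-substituted phenyl carries cyano in place of methylsulfanyl (a 2.7-fold higher number from compound 2 to compound 4 (0.43 log units; beyond the scatter)), which shows that the lower number of compound 2 does not come with every 4-substituted phenyl and that the group on that phenyl matters, with compound 2 alone standing apart among the four. The data shown offer no measurement that explains this difference.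

The compounds shown do not settle whether the lower number belongs to the sulfur-bearing methylsulfanyl group in particular, as a methoxy or ethylsulfanyl group at the same place on the phenyl could test. They also leave open how an amine or a carboxylic acid on that phenyl would read in this assay.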